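This account rests on a few compounds, and the source may have more. Where it says the series, first, only, none or still open, it means among the compounds named here.

Compound 3 `Cc1cc(=O)n(-c2ccc(F)c(F)c2)nc1C(=O)Nc1ccc(Oc2ncnc3ccsc23)cc1` gives the lowest number of the three measured in a functional assay on MCF7 cells (Homo sapiens) for cytotoxicity, read by MTT assay, with a stated time of 72 h (on this read-out lower numbers stand for stronger inhibition and higher numbers for weaker inhibition), at 5550 nM; compound 1 `Cc1cc(=O)n(-c2ccc(Br)cc2F)nc1C(=O)Nc1ccc(Oc2ncnc3ccsc23)cc1` gives 9360 nM and compound 2 `Cc1cc(=O)n(-c2ccccc2OC(F)(F)F)nc1C(=O)Nc1ccc(Oc2ncnc3ccsc23)cc1` gives 23800 nM, so that a 1.7-fold lower number from compound 1 to compound 3 (0.23 log units; within the scatter) and a 4.3-fold lower number from compound 2 to compound 3 (0.63 log units; beyond the scatter). Compound 4 `Cc1ccc(-n2nc(C(=O)Nc3ccc(Oc4ncnc5ccsc45)cc3)c(C)cc2=O)c(C)c1` differs from compound 3 in one place: 2,4-dimethylphenyl in place of 3,4-difluorophenyl on an aromatic nitrogen. The measured steps all swap one substituted phenyl for another on this nitrogen, and none of them introduces a methyl-bearing phenyl, so only their general size bears on the question. Compound 4 is therefore expected to show a modest step, a 1.6-fold higher number from compound 3 to compound 4 (0.21 log units; within the scatter), in this assay. Its estimate for compound 4 is 9000 nM, within a range from 3000 nM to 30000 nM.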

Compound 4, half-maximal inhibitory concentration: 11900 nM
Compound 4: the middle estimate sits 1.3-fold (0.12 log units) below what was measured; the range from low to high includes it.
By their numbers in this assay, from the lowest: compounds 3, 1, 4 and 2 (each within the scatter of the next, the first and the last beyond it).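

With 2,4-dimethylphenyl, which carries no fluorine, on this nitrogen, this assay gives a 2.1-fold higher number from compound 3 to compound 4 (0.33 log units; beyond the scatter), a step just beyond the scatter. Against the other two aryl groups the change stays within the scatter, at a 1.3-fold higher number from compound 1 to compound 4 (0.10 log units; within the scatter) and a 2.0-fold lower number from compound 2 to compound 4 (0.30 log units; within the scatter), so a substituted phenyl carrying only carbon fits within the span already set by the fluorinated ones. Nothing available explains these steps. As far as these compounds go, it remains open whether an amine or a carboxylic acid on this phenyl would leave that span. Also open is which of the two methyl groups accounts for the step away from compound 3.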